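Extending the ring substituent of compound 3 from methyl to ethyl

The source may hold more compounds than are shown below. What is called first, only, known or untested is meant among the compounds shown, and "the series" means these compounds.

Compound 1 `O=C(O)CC(Cc1nc2cc(F)ccc2[nH]1)c1ccc(Cl)cc1` — 30%
Compound 2 `O=C(O)CC(Cc1nc2cc(C(F)(F)F)ccc2[nH]1)c1ccc(Cl)cc1` — 85%
Compound 3 `Cc1ccc2[nH]c(CC(CC(=O)O)c3ccc(Cl)cc3)nc2c1` — 0%

In an assay on isolated protein for inhibition of protein kinase C zeta type (Homo sapiens), read by 33P incorporation, tested at 200 uM (on this read-out lower numbers stand for a weaker effect and higher numbers for a stronger effect at the one concentration tested), compound 3 stands lowest of the three measured compounds. Its nearest neighbour is compound 1, reached by a number 30 percentage points lower from compound 1 to compound 3 (beyond the scatter); the furthest is compound 2, reached by a number 85 percentage points lower from compound 2 to compound 3 (beyond the scatter). Between those two, a number 55 percentage points higher from compound 1 to compound 2 (beyond the scatter) was seen.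

Compound 4 `CCc1ccc2[nH]c(CC(CC(=O)O)c3ccc(Cl)cc3)nc2c1` differs from compound 3 by methyl in place of hydrogen on a saturated chain carbon bound to an aromatic carbon. Among the compounds with values here, no measured step changes the group at that site in this way: the three measured steps exchange fluoro, trifluoromethyl and methyl on the aromatic carbon, and they do not show that a larger group at this position raises the number, since trifluoromethyl gave the highest value while methyl gave the lowest. The expected step from methyl to ethyl is therefore small, with no direction supported beyond the scatter, so the account estimates a number 5 percentage points higher from compound 3 to compound 4 (within the scatter). Compound 4 is accordingly expected to give about 5% in this assay, within a range of 0% to 25%.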

Compound 4, a percentage reported as inhibition, at one concentration (the size of the read-out at that concentration, not a potency): 0%
Compound 4: the middle estimate sits 5 percentage points above what was measured; low and high end bracket the measured number.
By their numbers in this assay, from the lowest: compounds 3 and 4 (each within the scatter of the next); then compound 1; then compound 2.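

In this assay, extending methyl to ethyl gave no change at the digits printed from compound 3 to compound 4 (within the scatter), so adding a methyl on a saturated chain carbon bound to an aromatic carbon did not lift the read-out from where compound 3 left it. Ethyl also stands as far from the two halogen-bearing groups as methyl does, with a number 85 percentage points lower from compound 2 to compound 4 (beyond the scatter) and a number 30 percentage points lower from compound 1 to compound 4 (beyond the scatter), so both alkyl compounds lie beyond the scatter from fluoro and trifluoromethyl. Nothing available explains this separation or the lack of any step from methyl to ethyl.

With both alkyl compounds reading at the bottom of the scale at one concentration, any difference between them stays hidden. The compounds shown also leave open whether chloro, methoxy or a longer chain such as propyl would fall with the alkyl pair or nearer compound 2.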